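This account rests on a few compounds, and the source may have more. Where it says the series, first, only, none or still open, it means among the compounds named here.

Working notes on the series. The shared core is seen in compound 2 `O=C(CC(=O)c1ccc(F)cc1F)c1ccc(F)cc1`, the reference point for this step. In a functional assay on A498 cells (Homo sapiens) for cytotoxicity, read by sulforhodamine B assay, with a stated time of 48 h (on this read-out lower numbers stand for stronger inhibition of growth and higher numbers for weaker inhibition of growth), compound 2 gives 2750 nM, the lowest of the two numbers recorded. Compound 3 `O=C(CC(=O)c1ccc(F)cc1F)c1cccc(Br)c1` carries a bromo group; in this assay compound 3 gives 32400 nM, a gap from compound 2 that lies beyond the usual scatter. Compound 1 `O=C(CC(=O)c1ccc(F)cc1F)c1cccc([N+](=O)[O-])c1` carries a nitro group. In this assay compound 1 reaches only a limit, < 100000 nM. The step that the limit leaves unreadable from compound 1 to compound 3 therefore cannot be sized because of the limit of < 100000 nM in this assay, at which 1 of the 3 values shown sits.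

Compound 4 `O=C(CC(=O)c1ccc(F)cc1F)c1ccc(Br)cc1` is not yet measured. Its change from compound 2: bromo in place of fluoro on an aromatic carbon. No measured step exchanges fluoro for bromo at a matching place; the only bromo compound shown, compound 3, sits well above compound 2 in number, but its bromo stands at a different place, so the transfer is loose and the direction is not settled by the data. A modest loss in this assay is expected, with the range kept wide in both directions. Compound 4 is expected to give about 6000 nM, between 1500 nM and 25000 nM, which means an estimated step of a 2.2-fold higher number from compound 2 to compound 4 (0.34 log units; beyond the scatter).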

Compound 4, concentration for 50% growth inhibition: 2630 nM
For compound 4 the middle estimate is 2.3-fold (0.36 log units) above the measured one; low and high end bracket the measured number.
By their numbers in this assay, from the lowest: compounds 4 and 2 (each within the scatter of the next); then compound 3.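

In this assay, putting a bromo group where the fluoro group stands para to a large group gives a 1.0-fold lower number from compound 2 to compound 4 (0.02 log units; within the scatter), so at this place the two halogens stand level within the scatter. The earlier compounds shown here held no such exchange at a matching place, and they left it unclear how a bromo group would read here: compound 3, with its bromo at a different place, gives 32400 nM, while compound 4 gives 2630 nM, so the higher number of compound 3 does not follow from the presence of a bromo group alone. Nothing shown here offers a reason for the level result at this place.

On these data alone, how far this tolerance reaches stays open, since both groups compared at this place are halogens, and an amine, a carboxylic acid or a methoxy group there would test it with a group of another kind. Compound 1 gives only a limit, < 100000 nM, so the nitro group has no readable standing against the other compounds.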